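Inverting the ring stereocentre of compound 3

This account rests on a few compounds, and the source may have more. Where it says the series, first, only, none or still open, it means among the compounds named here.

In a functional assay on MIA PaCa-2 cells (Homo sapiens) for inhibition, read by MTT assay, with a stated time of 3 days (a lower number here means a stronger inhibitor, a higher number a weaker inhibitor), compound 1 (`CCN(CC)S(=O)(=O)c1ccc(S(=O)(=O)N2CCC[C@@H](C(=O)N3CCC(c4nc(C(C)C)no4)CC3)C2)cc1`) gives 30 nM and compound 2 (`CCN(CC)S(=O)(=O)c1ccc(S(=O)(=O)N2CCC[C@@H](C(=O)N3CCN(c4nc(C)no4)CC3)C2)cc1`) gives 200 nM as measured numbers. Compound 3 (`CCOC(=O)N1CCC[C@H](S(=O)(=O)c2ccc(S(=O)(=O)N(CC)CC)cc2)C1`) stands at > 10000 nM in this assay and this is a limit of the assay, not a number. Compound 4 (`CCOC(=O)N1CCC[C@@H](S(=O)(=O)c2ccc(S(=O)(=O)N(CC)CC)cc2)C1`) is reached by a single change: the two compounds have the same atoms and bonds and differ only in configuration as drawn: 1 of 1 stereo elements differ; a stereocentre at a saturated ring carbon is drawn S in compound 3 and R in compound 4 and nothing else. Within the data shown here, no measured pair shows what such an inversion is worth, so the data give no direct size for it. The expected step of an at least 1.2-fold lower number from compound 3 to compound 4 (0.09 log units; that floor lies within the scatter) is small, with at most a modest gain in strength and a real chance of no visible change. The expectation is anchored on compound 3 at > 10000 nM as a limit and on nothing more. Compound 4 is expected to remain a weak inhibitor, and a limit rather than a number is quite possible. For compound 4 the estimated value is 8000 nM with an expected range from 2000 nM to 30000 nM in this assay when a number is obtained.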

Compound 4, half-maximal inhibitory concentration: > 10000 nM
Compound 4: no number, only a limit; the forecaster's own chance of this, stated with the estimate: 55%; middle value at least 1.2-fold (0.09 log units) away from the limit.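

The step between compound 3 and compound 4 cannot be read, because both stand at a limit of the assay and not at a number: the limit of > 10000 nM in this assay, at which 2 of the 4 values shown sit. As far as these compounds go, what inverting the stereocentre at the saturated ring carbon is worth stays open.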